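Notes on the step from compound 2 to compound 3

A few compounds are considered here, and "the series" means these few. Any claim that something is new, unique, unknown or untested is made for them only; others in the source may bear on it.

Measured in a functional assay (trachea) with Cavia porcellus as the target; a lower number here means that less compound is needed, a higher number that more compound is needed for the effect:
compound 1 `CCCn1c(=O)n(C)c(=O)c2[nH]cnc21`: 1600 nM
compound 2 `CCCn1c(=O)n(C)c(=O)c2c1ncn2CCC#N`: 27600 nM

Of the two measured compounds, compound 2 (27600 nM) has the higher number, so more of it is needed for the effect. Compound 3 `CCCn1c(=O)n(C)c(=O)c2c1ncn2CCCN(C)C` differs from it by (dimethylamino)methyl in place of cyano on a saturated chain carbon, two bonds along the chain from an aromatic nitrogen so that 2-cyanoethyl becomes 3-(dimethylamino)propyl. This is (dimethylamino)methyl in place of cyano on a saturated chain carbon, two bonds along the chain from an aromatic nitrogen.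

Among the compounds with values here, only one measured step bears on this. The large 17-fold higher number from compound 1 to compound 2 (1.24 log units; beyond the scatter) came with 2-cyanoethyl in place of hydrogen on an aromatic nitrogen. Within the data shown here, that step replaced the hydrogen, whereas here only the end of the chain changes, and no measured step covers such a change. No step beyond the scatter is therefore expected, though with low confidence and a wide range in either direction. The expected step is a 1.1-fold lower number from compound 2 to compound 3 (0.04 log units; within the scatter) in this estimate. In this assay the estimate for compound 3 is 25000 nM (expected range 6000 nM to 90000 nM)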

Compound 3, half-maximal effective concentration: > 100000 nM
Compound 3 gave a limit, no number (the forecaster's own chance of this, stated with the estimate: 15%); middle value at least 4.0-fold (0.60 log units) from the limit.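

In this assay compound 3 gives no number, only a limit of the assay: the limit of > 100000 nM in this assay, at which 1 of the 3 values shown sits. The end of the chain on the aromatic nitrogen therefore matters in its own right, not just the replacement of the hydrogen: (dimethylamino)methyl in place of cyano gives an at least 3.6-fold higher number from compound 2 to compound 3 (0.55 log units; beyond the scatter). Replacing the hydrogen with 3-(dimethylamino)propyl gives an at least 62-fold higher number from compound 1 to compound 3 (1.79 log units; beyond the scatter), so both chains shown at this nitrogen, 2-cyanoethyl and 3-(dimethylamino)propyl, go the same way, with no compound shown going against it.

The full size of the step to compound 3 cannot be read from a limit. As far as these compounds go, it remains open whether a short methyl group on this nitrogen, or a hydroxyl or carboxylic acid at the chain end, would stay closer to the unsubstituted compound 1.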